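A few compounds are considered here, and "the series" means these few. Any claim that something is new, unique, unknown or untested is made for them only; others in the source may bear on it.

Going by the values given here, in a functional assay on MCF7 cells (Homo sapiens) for antiproliferative activity, read by MTT assay (a higher number here means a weaker inhibitor, a lower number a stronger inhibitor), two compounds have values so far. Compound 1 (`COc1ccc([C@@H]2[C@@H](c3cccs3)C(=O)N2c2cc(OC)c(OC)c(OC)c2)cc1N`) gives 42 nM. Compound 2 (`COc1ccc([C@@H]2[C@@H](C(O)c3cccs3)C(=O)N2c2cc(OC)c(OC)c(OC)c2)cc1`) gives 1200 nM, the higher of the two numbers, and its gap to compound 1 lies beyond the scatter. Compound 3 (`COc1ccc([C@@H]2[C@@H](C(=O)c3cccs3)C(=O)N2c2cc(OC)c(OC)c(OC)c2)cc1`) is not yet measured and differs from compound 2 in one place, on a saturated ring carbon of the four-membered non-aromatic ring: (thiophen-2-yl)carbonyl in place of hydroxy(thiophen-2-yl)methyl, ((thiophen-2-yl)carbonyl in place of hydroxy(thiophen-2-yl)methyl on a saturated ring carbon). Among the compounds with values here, no measured pair shows this change, so the step rests on judgement alone. A moderate move toward a lower number in this assay is expected, with a change within the scatter not excluded. The expected step is a 2.7-fold lower number from compound 2 to compound 3 (0.43 log units; beyond the scatter). For compound 3, the estimated value is 450 nM, with an expected range from 90 nM to 2000 nM.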

Compound 3, half-maximal inhibitory concentration: 950 nM
Estimate against measurement, compound 3: 2.1-fold (0.32 log units) below, and the stated range covers the measured number.
By their numbers in this assay, from the lowest: compound 1; then compounds 3 and 2 (each within the scatter of the next).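

In this assay, (thiophen-2-yl)carbonyl in place of hydroxy(thiophen-2-yl)methyl on the saturated ring carbon of the four-membered ring gives a 1.3-fold lower number from compound 2 to compound 3 (0.10 log units; within the scatter), so this read-out does not separate the two groups at this position. The change removes the hydrogen-bond donor of the group while the hydrogen-bond acceptor count and the heavy-atom count stay the same, and in this one pair the loss of that donor leaves the number within the scatter. Nothing measured on these compounds gives a reason for this outcome.

Compound 1, at 42 nM, differs from compound 2 and from compound 3 in more than one place, so its gap to them cannot be assigned to this position alone. As far as these compounds go, it remains open whether an aminomethyl group, a carboxylic acid or a longer chain on this ring carbon would move the number beyond the scatter.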